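Dithiocarbamate butenolides: diethylamino to pyrrolidinyl

This account rests on a few compounds, and the source may have more. Where it says the series, first, only, none or still open, it means among the compounds named here.

Among the measured compounds shown here, compound 1 `CCN(CC)C(=S)SCC1=CCOC1=O` is the only member of this set with a numerical result: in a functional assay on EC9706 cells (Homo sapiens) for antiproliferative activity, read by MTT assay, with a stated time of 72 h (a lower number here means a stronger inhibitor, a higher number a weaker inhibitor), compound 1 gives 136000 nM. Compound 2 `O=C1OCC=C1CSC(=S)Nc1ccc(Cl)cc1`, which carries an anilino-type dithiocarbamate on the same core, is reported in this assay as "not active" (no number reported), with no number attached, so no comparison of size between compound 1 and compound 2 can be made. Compound 1 therefore stands alone on the numbers, and its value is a weak one.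

Compound 3 `O=C1OCC=C1CSC(=S)N1CCCC1` differs from compound 1 in one place: pyrrolidin-1-yl in place of diethylamino on a thiocarbonyl carbon. For the measured compounds named here, no measured pair in the set shows what such a change does in this assay, so the expected step from compound 1 to compound 3 rests on nothing but the small size of the change. The expectation is that the step of a 1.0-fold lower number from compound 1 to compound 3 (0.02 log units; within the scatter) stays within the usual scatter, with no firm direction. Compound 3 is accordingly estimated at 130000 nM in this assay, with a range from 50000 nM to 400000 nM, and a real chance that only an inactive call is reported, as happened for compound 2.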

Compound 3, half-maximal inhibitory concentration: 14400 nM
Compound 3: middle estimate off by 9.0-fold (0.96 log units), on the high side, outside the stated range (below it).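

On the thiocarbonyl carbon, the group attached through nitrogen is not a silent position: in this assay, pyrrolidin-1-yl in place of diethylamino gives a 9.4-fold lower number from compound 1 to compound 3 (0.98 log units; beyond the scatter) and provides the first numerical read on a change at this place in the series. The two groups match in the counts of heavy atoms, carbon, nitrogen, hydrogen-bond donors and hydrogen-bond acceptors, and neither carries a net charge, so a change that leaves these counts untouched and adds one five-membered non-aromatic ring can still move the result beyond the scatter. No measurement at hand bears on the reason for this step.

As far as these compounds go, it remains open whether the lower number belongs to a ring on this nitrogen in general or to pyrrolidin-1-yl in particular, and piperidin-1-yl or morpholin-4-yl on the same thiocarbonyl carbon would separate those two readings. From the compounds shown here alone, the step also rests on a single pair in one cell line, so whether it carries over to a different core or another cell line stays unknown, while compound 2 still gives no number against which the anilino-type group could be sized.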